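A few compounds are considered here, and "the series" means these few. Any claim that something is new, unique, unknown or untested is made for them only; others in the source may bear on it.

Compound 1 `COc1ccc(C(=O)/C=C/c2cc(-c3cc(OC)c(OC)c(OC)c3)n3nc(-c4ccccc4)cc3n2)cc1`: in a functional assay on A549 cells (Homo sapiens) for antiproliferative activity, read by MTT assay, with a stated time of 24 h (on this read-out lower numbers stand for stronger inhibition and higher numbers for weaker inhibition), compound 1 gives 14600 nM.
Compound 2 `COc1cc(-c2cc(C(=O)/C=C/c3ccc(Cl)cc3)nc3cc(-c4ccccc4)nn23)cc(OC)c1OC`: in this assay compound 2 gives 23800 nM.
Compound 3 `COc1cc(-c2cc(C(=O)/C=C/c3ccccc3)nc3cc(-c4ccccc4)nn23)cc(OC)c1OC`: in this assay compound 3 gives 18000 nM.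

Among these three numbers compound 3 stands second highest, with compound 1 nearest and compound 2 furthest, and both of its neighbours lie within the scatter of it. Compound 4 `COc1cc(-c2cc(/C=C/C(=O)c3ccc(C)cc3)nc3cc(-c4ccccc4)nn23)cc(OC)c1OC` keeps the shared core of compound 3 and differs only in the enone arm: 2-((4-methylphenyl)carbonyl)ethenyl in place of (2-phenylethenyl)carbonyl on an aromatic carbon. Within the data shown here, the closest precedent is compound 1, whose arm already carries the reversed arrangement with a 4-methoxyphenyl group; the change from compound 1 to compound 3 gave a 1.2-fold higher number from compound 1 to compound 3 (0.09 log units; within the scatter). The other two steps, a 1.6-fold higher number from compound 1 to compound 2 (0.21 log units; within the scatter) and a 1.3-fold lower number from compound 2 to compound 3 (0.12 log units; within the scatter), are likewise within the scatter, so no variation of this arm among the measured compounds has moved the number beyond noise. Compound 4 is therefore expected to sit close to compound 3, with a step of a 1.2-fold lower number from compound 3 to compound 4 (0.06 log units; within the scatter), that is, no shift beyond the scatter. For compound 4 the estimated value in this assay is 15500 nM, within a range from 7000 nM to 34000 nM.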

Compound 4, half-maximal inhibitory concentration: 19400 nM
Beside the measured number, compound 4's estimate is 1.3-fold (0.10 log units) below it; low and high end bracket the measured number.
By their numbers in this assay, from the lowest: compounds 1, 3, 4 and 2 (each within the scatter of the next).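

In this assay, among these compounds, the reversed arm now appears with a second ring substituent, and methyl in place of methoxy on an aromatic carbon gives a 1.3-fold higher number from compound 1 to compound 4 (0.12 log units; within the scatter) for this arm, the first reading of a change on its terminal ring. The same arm can also now be set directly against the other orientation: 2-((4-methylphenyl)carbonyl)ethenyl in place of (2-phenylethenyl)carbonyl gives a 1.1-fold higher number from compound 3 to compound 4 (0.03 log units; within the scatter) and, in place of (2-(4-chlorophenyl)ethenyl)carbonyl, gives a 1.2-fold lower number from compound 2 to compound 4 (0.09 log units; within the scatter) on this position, so neither the orientation of the arm nor the methyl, methoxy, chloro or hydrogen on its ring separates any of these compounds beyond the scatter.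

The compounds shown leave open whether a group of another kind on that terminal ring, such as an amine or a carboxylic acid, or a longer chain in place of the ethenyl link, would move the number beyond the scatter in this assay. Going by these compounds, all the numbers also come from one cell line at one stated time, so whether these arms remain indistinguishable in other cells or at other times stays open. No measurement at hand speaks to why the numbers stay so close.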